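Triazole substituent series, antiproliferative read-out

A few compounds are considered here, and "the series" means these few. Any claim that something is new, unique, unknown or untested is made for them only; others in the source may bear on it.

compound 1 `O=C1NC(O)(CCn2cc(C3=CCCCC3)nn2)C(OCc2ccccc2)=C1OCc1ccccc1` — 67200 nM
compound 2 `CC(C)(C)c1ccc(-c2cn(C/C=C3\OC(=O)C(OCc4ccccc4)=C3OCc3ccccc3)nn2)cc1` — > 100000 nM
compound 3 `O=C1NC(O)(CCn2cc(-c3ccccc3)nn2)C(OCc2ccccc2)=C1OCc1ccccc1` — > 100000 nM

In a functional assay on PC-3 cells (Homo sapiens) for antiproliferative activity, read by MTT assay, with a stated time of 24 h (on this read-out higher numbers stand for weaker inhibition and lower numbers for stronger inhibition), compound 1 gives 67200 nM. For compound 3 the read-out is a limit of the assay, > 100000 nM, not a number. For compound 2 the read-out is likewise only a limit, > 100000 nM. Compound 3 thus stands at the limit, where one of the two other values also sits, and the step of an at least 1.4-fold higher number from compound 1 to compound 3 (0.17 log units; that floor lies within the scatter) is itself only a floor (the limit of > 100000 nM in this assay, at which 2 of the 3 values shown sit).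

Compound 4 `CC(C)(C)c1ccc(-c2cn(CCC3(O)NC(=O)C(OCc4ccccc4)=C3OCc3ccccc3)nn2)cc1` differs from compound 3 by tert-butyl in place of hydrogen on an aromatic carbon. Among the compounds with values here, the one measured step, an at least 1.4-fold higher number from compound 1 to compound 3 (0.17 log units; that floor lies within the scatter), concerns a different exchange and is a floor, so it bears on the present step only through the starting point of compound 3. Compound 2 carries the same tert-butyl-bearing aryl group on another core and returns only a limit. No step beyond the scatter is therefore expected for a step that the limit leaves unreadable from compound 3 to compound 4. Compound 4 is estimated at 150000 nM, within 60000 nM to 400000 nM, most likely again reported as a limit.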

Compound 4, half-maximal inhibitory concentration: 43000 nM
Compound 4: the middle estimate sits 3.5-fold (0.54 log units) above what was measured; the whole stated range lies above it.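

In this assay, within the data shown here, this position responds to substitution on the aromatic ring: tert-butyl in place of hydrogen gives an at least 2.3-fold lower number from compound 3 to compound 4 (0.36 log units; beyond the scatter), the first step that clears the scatter. From the compounds shown here alone, its true size stays unknown, and it reads only as a floor, since the value of compound 3 is a limit of the assay: the limit of > 100000 nM in this assay, at which 2 of the 4 values shown sit. Against the non-aromatic alternative the outcome differs, with a 1.6-fold lower number from compound 1 to compound 4 (0.19 log units; within the scatter), so 4-(tert-butyl)phenyl and cyclohex-1-en-1-yl are not separated at this position.

Open, going by these compounds, is whether a methyl group, an amine or a carboxylic acid on the same aromatic carbon would shift the read-out as tert-butyl does. Also open, on these data alone, is whether a longer chain between the shared core and the aryl-bearing ring would change it.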